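A few compounds are considered here, and "the series" means these few. Any claim that something is new, unique, unknown or untested is made for them only; others in the source may bear on it.

Measured compounds in an ADME assay on HepG2 cells (Homo sapiens) for cytotoxicity, read by CellTiter-Glo and resazurin assay, with a stated time of 72 h; a higher number here means that more compound is needed for the effect, a lower number that less compound is needed:
Compound 1, `CC(C)COc1cccc(-c2ccc(C(=O)N(Cc3cccc(OCCCCCC(=O)O)c3)C(C)C)cc2)c1`: in this assay compound 1 gives > 26000 nM, a limit of the assay.
Compound 2, `CC(C)N(Cc1cccc(OCCCCCC(=O)O)c1)C(=O)c1ccc(-c2cccc(OCc3ccccc3)c2)cc1`: in this assay compound 2 gives > 26000 nM, a limit of the assay.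
Compound 3, `CC(C)N(Cc1cccc(OCCCCCC(=O)O)c1)C(=O)c1ccc(-c2cc3ccccc3n2S(=O)(=O)c2ccccc2)cc1`: in this assay compound 3 gives > 26000 nM, a limit of the assay.

Compound 2 therefore stands at the limit, and the two other values shown are limits as well; all three sit at the limit of > 26000 nM in this assay, at which 3 of the 3 values shown sit. For the measured compounds named here, the only step between two measured compounds, phenyl in place of isopropyl on a saturated chain carbon bound to an oxygen on an aromatic ring, is a step that the two limits leave unreadable from compound 1 to compound 2, so its size is not readable.

Compound 4, `CC(C)N(Cc1cccc(OCCCCCC(=O)O)c1)C(=O)c1ccc(-c2cccc(F)c2)cc1`, is yet to be measured in this assay. It differs from compound 2 by fluoro in place of benzyloxy on an aromatic carbon.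

No measured step reads as a number, so nothing shows a change in this assay beyond the scatter; every shown value sits at the limit of > 26000 nM in this assay, at which 3 of the 3 values shown sit. The expectation for the step in this assay is therefore no change beyond the scatter, with compound 4 again most likely reported only as a limit. The estimated step from compound 2 to compound 4 is a step that the limit leaves unreadable from compound 2 to compound 4. For compound 4 the estimate is 40000 nM, in the range 20000 nM to 100000 nM.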

Compound 4, half-maximal effective concentration: > 26000 nM
Compound 4 was reported as a limit (the forecaster's own chance of this, stated with the estimate: 85%); the middle value does not contradict the limit.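

Compound 4 gives > 26000 nM, a limit of the assay, so its steps from compound 2 and compound 1 cannot be read. The compounds shown leave open whether any change to the shared core shifts the concentration needed for the effect in this assay: the limit of > 26000 nM in this assay, at which 4 of the 4 values shown sit.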